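Compound 1 to compound 3: hydrogen for fluoro

This account rests on a few compounds, and the source may have more. Where it says the series, first, only, none or still open, it means among the compounds named here.

Going by the values given here, in an ADME assay (liver) for metabolic stability, with Liver microsome (Homo sapiens) as the target, read by LC-MS, using microsomes, with a stated time of 1 h, tested at 5 uM (on this read-out higher numbers stand for a more stable compound and lower numbers for a less stable compound), compound 1 `Cc1nc(-c2ccccc2F)c(C(=O)N2CCN(c3cc(Cl)cc(Cl)c3)CC2)o1` gives 82.3%, the higher of the two numbers so far, and compound 2 `COc1cc(OC)cc(N2CCN(C(=O)c3oc(C)nc3-c3ccccc3F)CC2)c1` gives 15%. Among the compounds with values here, the sole measured step, a number 67.3 percentage points lower from compound 1 to compound 2 (beyond the scatter), is large, but it concerns the 3,5-dichlorophenyl group and bears only indirectly on the change here. Compound 3 `Cc1nc(-c2ccccc2)c(C(=O)N2CCN(c3cc(Cl)cc(Cl)c3)CC2)o1` has hydrogen in place of fluoro on an aromatic carbon, ortho to a large group: hydrogen in place of fluoro on an aromatic carbon. It retains the 3,5-dichlorophenyl group of compound 1 at 82.3%, so no large drop is expected. The estimated step, a number 7.3 percentage points lower from compound 1 to compound 3 (within the scatter), is small and leans lower. Compound 3 is estimated at 75%, with an expected range of 52% to 92%.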

Compound 3, percent of the compound remaining: 66.3%
Compound 3: middle estimate off by 8.7 percentage points, on the high side, within the range that was stated.
By their numbers in this assay, from the lowest: compound 2; then compound 3; then compound 1.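

In this assay the change from 2-fluorophenyl to phenyl gives a number 16 percentage points lower from compound 1 to compound 3 (beyond the scatter) on the 3,5-dichlorophenyl background, so this place, ortho to a large group, does affect the read-out. Going by these compounds alone, the earlier step showed only a change at the 3,5-dichlorophenyl group, and this step is the first at the other aromatic ring. Nothing measured here explains the step.

Going by these compounds, whether a methoxy group or an amine at this place would match fluoro remains open. Also open, on these data alone, is whether the same change would give a similar step with the 3,5-dimethoxyphenyl group of compound 2.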